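Benzyl carbamate exchanged for butyl carbamate

This account rests on a few compounds, and the source may have more. Where it says the series, first, only, none or still open, it means among the compounds named here.

Compound 2 `N#C[Se]c1ccc(NC(=O)OCc2ccccc2)cc1` stands second highest of the three numbers in an ADME assay on BEAS-2B cells (Homo sapiens) for cytotoxicity, read by MTT assay, with a stated time of 72 h (on this read-out lower numbers stand for stronger inhibition of growth and higher numbers for weaker inhibition of growth), where compound 2 gives 100 nM. Going by the values given here, compound 1 `N#C[Se]c1ccc(NC(=O)OCc2ccc([N+](=O)[O-])cc2)cc1` carries a nitro on an aromatic carbon; in this assay compound 1 gives 7700 nM, and the only measured step, a 77-fold lower number from compound 1 to compound 2 (1.89 log units; beyond the scatter), is the removal of that nitro. Among the compounds with values here, compound 3 `O=C(Nc1ccc([Se][Se]c2ccc(NC(=O)OCc3ccccc3)cc2)cc1)OCc1ccccc1` gives 10 nM in this assay, the lowest of the three numbers; no single-change step links compound 3 to compound 2, so only the two values can be compared.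

Compound 4 `CCCCOC(=O)Nc1ccc([Se]C#N)cc1` differs from compound 2 by propyl in place of phenyl on a saturated chain carbon bound to an oxygen next to a carbonyl group. Within the data shown here, no measured step touches the saturated chain carbon bound to an oxygen next to a carbonyl group: the step of a 77-fold lower number from compound 1 to compound 2 (1.89 log units; beyond the scatter) concerns the aromatic carbon, so the series gives no guide for this change. The expected step in this assay is therefore none beyond the scatter, a 2.0-fold higher number from compound 2 to compound 4 (0.30 log units; within the scatter), with a wide range. Compound 4 is estimated at 200 nM, between 40 nM and 1500 nM.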

Compound 4, concentration for 50% growth inhibition: 5000 nM
Estimate against measurement, compound 4: 25-fold (1.40 log units) below, and the stated range ends below it.
By their numbers in this assay, from the lowest: compound 3; then compound 2; then compounds 4 and 1 (each within the scatter of the next).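

In this assay, going by these compounds alone, the step of a 50-fold higher number from compound 2 to compound 4 (1.70 log units; beyond the scatter) is the first measured change on the saturated chain carbon bound to an oxygen next to a carbonyl group, and it shows that propyl does not stand in for phenyl at this place without a large rise in the number. Within the data shown here, until now the only measured step, a 77-fold lower number from compound 1 to compound 2 (1.89 log units; beyond the scatter), concerned an aromatic carbon; the series now has a large step on the chain carbon as well. No measured evidence is available on what lies behind the new step.

Whether the loss of the ring or the shorter group accounts for the step stays open: a cyclohexyl group or a longer chain on that carbon would separate the two. As far as these compounds go, whether butyl carbamate behaves the same way in the diselenide form of compound 3 is also open.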